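The source may report more compounds than this note shows. Statements on the series, on what has been measured and on what is new or still open speak of the compounds shown alone.

Measured compounds in an ADME assay on CCRF-HSB-2 cells (Homo sapiens) for cytotoxicity, with a stated time of 7 days; on this read-out higher numbers stand for lower toxicity in this test and lower numbers for higher toxicity in this test:
- compound 1 `C=CCOc1nc(N)nc2c1ncn2/C=C1/CC1(CO)CO` — > 20000 nM
- compound 2 `COCCOc1nc(N)nc2c1ncn2/C=C1/CC1(CO)CO` — > 20000 nM
- compound 3 `Nc1nc(NC2CC2)c2ncn(/C=C3/CC3(CO)CO)c2n1` — > 20000 nM

In this assay compound 1 gives only > 20000 nM, a limit of the assay and not a number. Compound 2 also gives a limit, > 20000 nM. Compound 3 gives a limit as well, > 20000 nM. All three values therefore sit at the limit of > 20000 nM in this assay, at which 3 of the 3 values shown sit, and compound 1 stands nowhere above or below its neighbours on the numbers shown.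

Compound 4 is `CCCCOc1nc(N)nc2c1ncn2/C=C1/CC1(CO)CO`. It differs from compound 1 by propyl in place of vinyl on a saturated chain carbon bound to an oxygen on an aromatic ring. Among the compounds with values here, the only measured step at the same place is a step that the two limits leave unreadable from compound 1 to compound 2; the other two steps, a step that the two limits leave unreadable from compound 1 to compound 3 and a step that the two limits leave unreadable from compound 2 to compound 3, change a different position and are equally unreadable. Within the data shown here, no measured step therefore gives a readable size, and every value met so far is a limit. Compound 4 is expected to behave the same way, with a step that the limit leaves unreadable from compound 1 to compound 4, that is none beyond the scatter. Compound 4 is estimated at 40000 nM, within 20000 nM to 100000 nM, most likely reported again as a limit.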

Compound 4, half-maximal cytotoxic concentration: > 20000 nM
Compound 4: only a limit was reported; the forecaster's own chance of this, stated with the estimate: 90%; the middle value is on the limit's open side.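

In this assay compound 4 gives > 20000 nM, a limit of the assay and not a number. Its steps to compound 1, compound 2 and compound 3 cannot be read: the limit of > 20000 nM in this assay, at which 4 of the 4 values shown sit.

The compounds shown leave open whether these four compounds differ at all in toxicity in this test.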